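This account rests on a few compounds, and the source may have more. Where it says the series, first, only, none or still open, it means among the compounds named here.

Measured in an ADME assay on a cell-free system (plasma, Homo sapiens) for metabolic stability, read by LC-MS, with a stated time of 60 min, at 37 degrees C, tested at 50 uM; on this read-out lower numbers stand for a less stable compound and higher numbers for a more stable compound:
- compound 1 `Cc1oc(=O)oc1COC(=O)C1=C(S[C@@H]2CN[C@H](C(=O)Nc3cccc(C(=O)OCc4oc(=O)oc4C)c3)C2)[C@H](C)[C@@H]2[C@@H]([C@@H](C)O)C(=O)N12`: 1%
- compound 2 `C[C@@H](O)[C@H]1C(=O)N2C(C(=O)OCOC(=O)OC(C)(C)C)=C(S[C@@H]3CN[C@H](C(=O)Nc4cccc(C(=O)O)c4)C3)[C@H](C)[C@H]12`: 40%
- compound 3 `C[C@@H](O)[C@H]1C(=O)N2C(C(=O)OCOC(=O)OC(C)(C)C)=C(S[C@@H]3CN[C@H](C(=O)Nc4cccc(C(=O)OCOC(=O)OC(C)(C)C)c4)C3)[C@H](C)[C@H]12`: 67%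

In this assay compound 2 stands second highest of the three numbers; its nearest neighbour is compound 3, a number higher by a number 27 percentage points higher from compound 2 to compound 3 (beyond the scatter), and its furthest is compound 1, whose value of 1% lies well below that of compound 2.

Compound 4 `CC(C)OC(=O)OCOC(=O)C1=C(S[C@@H]2CN[C@H](C(=O)Nc3cccc(C(=O)O)c3)C2)[C@H](C)[C@@H]2[C@@H]([C@@H](C)O)C(=O)N12` is not yet measured. It differs from compound 2 as follows: hydrogen in place of methyl on a saturated chain carbon bound to an oxygen next to a carbonyl group and two saturated chain carbons.

Among the compounds with values here, the only measured step, a number 27 percentage points higher from compound 2 to compound 3 (beyond the scatter), concerns a different place, the oxygen next to a carbonyl group on the ring-bound acid, where a ((tert-butoxycarbonyl)oxy)methyl group enters; no measured pair shows the tert-butyl to isopropyl change. There is therefore no direct guide for the step from compound 2 to compound 4. With nothing to indicate otherwise, the expected change in this assay is none beyond the scatter, estimated as a number 4 percentage points lower from compound 2 to compound 4 (within the scatter).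

Compound 4 is thus expected to give 36% in this assay, within an estimated range from 22% to 50%.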

Compound 4, percent of the compound remaining: 62%
For compound 4 the middle estimate is 26 percentage points below the measured one, and the stated range ends below it.
By their numbers in this assay, from the lowest: compound 1; then compound 2; then compounds 4 and 3 (each within the scatter of the next).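

In this assay the change from tert-butoxycarbonyl to isopropoxycarbonyl gives a number 
a number 22 percentage points higher from compound 2 to compound 4 (beyond the scatter), so removing a single methyl at this place on the saturated chain carbon is enough to register. The earlier step, a number 27 percentage points higher from compound 2 to compound 3 (beyond the scatter), concerned a different place, and this result shows that the far end of the ester group on compound 2 also bears on the read-out. Nothing at hand explains the direction of this step.

Going by these compounds, whether an ethoxycarbonyl or a methoxycarbonyl group at this place would follow compound 4 remains open, as does the effect of a longer chain. Also open, on these data alone, is whether the tert-butyl to isopropyl change would give a similar step with the free carboxylic acid of compound 4 capped, as it is in compound 3.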